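A few compounds are considered here, and "the series" means these few. Any claim that something is new, unique, unknown or untested is made for them only; others in the source may bear on it.

Measured so far in a functional assay on MGC-803 cells (Homo sapiens) for inhibition, read by CCK-8 assay, with a stated time of 48 h; a higher number here means a weaker inhibitor, a lower number a stronger inhibitor:
- compound 1 `COc1ccc(CN(C(=O)CSC(=S)N2CCc3ccccc32)c2cc(OC)c(OC)c(OC)c2)cc1`: 8410 nM
- compound 2 `COc1ccc(CN(C(=O)CSC(=S)N2CCc3cc(OC)ccc32)c2cc(OC)c(OC)c(OC)c2)cc1`: 11700 nM

Compound 2 at 11700 nM stands within the scatter of compound 1 at 8410 nM, so the two cannot be ranked. The next compound, compound 3 `COc1ccc(CN(C(=O)CSC(=S)N2CCCc3cc(C)ccc32)c2cc(OC)c(OC)c(OC)c2)cc1`, differs from compound 2 at the thiocarbonyl carbon: 6-methyl-1,2,3,4-tetrahydroquinolin-1-yl in place of 5-methoxy-2,3-dihydro-1H-indol-1-yl on a thiocarbonyl carbon.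

Going by the values given here, only one measured step bears on this. It is a 1.4-fold higher number from compound 1 to compound 2 (0.14 log units; within the scatter), methoxy in place of hydrogen on an aromatic carbon, and it stays within the scatter. On that evidence, losing the methoxy is not expected to move the number much in this assay. Among the compounds with values here, the data hold no measured step for going from a five-membered to a six-membered non-aromatic ring, or for a methyl group, so that part of the change remains open and the range has to stay wide. No step beyond the scatter is expected, and no direction can be firmly argued. The estimated step is a 1.2-fold lower number from compound 2 to compound 3 (0.09 log units; within the scatter). For compound 3 the expected value is 9500 nM, with an estimated range of 3500 nM to 25000 nM.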

Compound 3, half-maximal inhibitory concentration: 6490 nM
Estimate against measurement, compound 3: 1.5-fold (0.17 log units) above; the range from low to high includes it.
By their numbers in this assay, from the lowest: compounds 3, 1 and 2 (each within the scatter of the next).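

At the thiocarbonyl carbon, in this assay, the 6-methyl-1,2,3,4-tetrahydroquinolin-1-yl group of compound 3 brings a six-membered non-aromatic ring to this position, and the steps from both groups with a five-membered non-aromatic ring stay within the scatter: replacing 5-methoxy-2,3-dihydro-1H-indol-1-yl gives (a 1.8-fold lower number from compound 2 to compound 3 (0.26 log units; within the scatter)), and replacing 2,3-dihydro-1H-indol-1-yl gives (a 1.3-fold lower number from compound 1 to compound 3 (0.11 log units; within the scatter)). This position therefore accepts a change of ring size made together with a methyl group on the aromatic ring, with no step beyond the scatter among the three compounds, which remain unranked. No supporting measurement accounts for these numbers.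

Ring size and the methyl group enter together in compound 3, so their separate contributions remain unresolved, and the 1,2,3,4-tetrahydroquinolin-1-yl group without the methyl would be the direct comparison. Also open, as far as these compounds go, is whether a carboxylic acid or a dimethylamino group on the aromatic ring, or a morpholine ring at the thiocarbonyl carbon, would move the number beyond the scatter in this assay at this position.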